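This account rests on a few compounds, and the source may have more. Where it says the series, first, only, none or still open, it means among the compounds named here.

In a functional assay on K562 cells (Homo sapiens) for cytotoxicity, read by ELISA, with a stated time of 4 days (on this read-out lower numbers stand for stronger inhibition and higher numbers for weaker inhibition), compound 1 `Cc1cccc(-c2cc(-c3ccoc3)cc(-c3ccc(Cl)s3)n2)c1` gives 13700 nM and compound 2 `Clc1ccc(-c2cc(-c3ccoc3)cc(-c3ccc(Cl)s3)n2)cc1` gives 19600 nM. These two numbers lie within the usual scatter of each other, so compound 2 stands level with compound 1, and no order can be read between them.

Compound 3 `Clc1ccc(-c2cc(-c3ccoc3)cc(-c3cccnc3)n2)s1` keeps the rest of compound 2 and differs in one place, on an aromatic carbon next to the ring nitrogen, where pyridin-3-yl stands in place of 4-chlorophenyl: pyridin-3-yl in place of 4-chlorophenyl on an aromatic carbon.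

For the measured compounds named here, only one measured step bears on this change. It lies at the same place, where 4-chlorophenyl replaces 3-methylphenyl, and it amounts to a 1.4-fold higher number from compound 1 to compound 2 (0.16 log units; within the scatter). That swap of one group for another left the number within the scatter. Going by the values given here, no measured compound carries pyridin-3-yl there, however, so this single step offers only thin guidance. A shift beyond the scatter in this assay is therefore not expected, and the direction remains uncertain.

The expected change is a 1.4-fold lower number from compound 2 to compound 3 (0.15 log units; within the scatter). For compound 3 the estimated value is 14000 nM, with an expected range from 4000 nM to 45000 nM.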

Compound 3, half-maximal inhibitory concentration: 18700 nM
The estimate for compound 3 lay 1.3-fold (0.13 log units) below the measured number, and the stated range covers the measured number.
By their numbers in this assay, from the lowest: compounds 1, 3 and 2 (each within the scatter of the next).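

In this assay, pyridin-3-yl at this place gives a 1.0-fold lower number from compound 2 to compound 3 (0.02 log units; within the scatter), and the comparison with the 3-methylphenyl compound gives a 1.4-fold higher number from compound 1 to compound 3 (0.14 log units; within the scatter), so neither step leaves the scatter. The earlier pair compared only six-membered aromatic rings of carbon, whereas this result shows that a ring with one nitrogen, counted as one hydrogen-bond acceptor, can enter here and the number still stands level with those of 3-methylphenyl and 4-chlorophenyl. Nothing available explains why these three groups stand level.

Going by these compounds, all three groups at this place are six-membered aromatic rings, so it remains open whether an amine, a carboxylic acid or a longer chain there would move the number beyond the scatter. The furan-3-yl group stays the same across compound 1, compound 2 and compound 3, so these compounds also cannot tell whether a change at that group would matter more than the changes seen here.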